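Aryl triazole esters of the shared core: compound 3 to compound 4

The compounds below may be only part of what the source reports. "The series", "measured", "known", "first", "only" and "open" are said of these compounds alone.

The series keeps one core and varies only the ring attached to the triazole nitrogen. Compound 1 `C/C(=C\CC/C(C)=C/CC[C@@H]1[C@@]2(C)CCC(=O)C(C)(C)[C@H]2CC[C@@]1(C)O)CC/C=C(\C)C(=O)OCc1cn(-c2ccccc2)nn1` carries a plain phenyl there and gives 95500 nM in a functional assay on DU-145 cells (Homo sapiens) for antiproliferative activity, read by MTT assay, with a stated time of 48 h; a lower number here means a stronger inhibitor, a higher number a weaker inhibitor. Compound 2 `C/C(=C\CC/C(C)=C/CC[C@@H]1[C@@]2(C)CCC(=O)C(C)(C)[C@H]2CC[C@@]1(C)O)CC/C=C(\C)C(=O)OCc1cn(-c2ccc(Br)cc2)nn1` carries a 4-bromophenyl. In this assay compound 2 gives only a limit of the assay, > 150000 nM. Compound 3 `C/C(=C\CC/C(C)=C/CC[C@@H]1[C@@]2(C)CCC(=O)C(C)(C)[C@H]2CC[C@@]1(C)O)CC/C=C(\C)C(=O)OCc1cn(-c2ccc(F)cc2)nn1` carries a 4-fluorophenyl. In this assay compound 3 also gives only a limit, > 150000 nM, so compound 3 stands at the top edge of what the assay reports, with no number of its own; it shares that position with one other value, as the limit of > 150000 nM in this assay, at which 2 of the 3 values shown sit, records.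

Compound 4 `C/C(=C\CC/C(C)=C/CC[C@@H]1[C@@]2(C)CCC(=O)C(C)(C)[C@H]2CC[C@@]1(C)O)CC/C=C(\C)C(=O)OCc1cn(-c2ccccc2Br)nn1` is the next member. Its change from compound 3 is 2-bromophenyl in place of 4-fluorophenyl on an aromatic nitrogen, the bromine now sitting next to the ring nitrogen rather than at the position occupied in compound 2.

For the measured compounds named here, the steps that bear on it are an at least 1.5-fold higher number from compound 1 to compound 2 (0.19 log units; that floor lies within the scatter) and an at least 1.5-fold higher number from compound 1 to compound 3 (0.19 log units; that floor lies within the scatter), both of which end at the limit, and a step that the two limits leave unreadable from compound 2 to compound 3, which the two limits leave unreadable. Neither halogen at the position used so far returned a number. Moving the bromine to the other position gives no measured guide, so no step beyond the scatter is expected, and compound 4 is estimated at 150000 nM, with a range from 80000 nM to 300000 nM. The expected step is a number no higher from compound 3 to compound 4 (the limit leaves the size open).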

Compound 4, half-maximal inhibitory concentration: > 150000 nM
Compound 4: no number, only a limit (the forecaster's own chance of this, stated with the estimate: 65%); the middle value sits exactly at the limit.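

The limit is now reached with 2-bromophenyl as well as with 4-bromophenyl and 4-fluorophenyl, so every halogen-bearing aryl group shown sits at the top edge of the assay, and the plain phenyl of compound 1 alone returns a number: the limit of > 150000 nM in this assay, at which 3 of the 4 values shown sit.

For the compounds shown here, the one step that can be read is an at least 1.5-fold higher number from compound 1 to compound 4 (0.19 log units; that floor lies within the scatter), so no change beyond the scatter can be claimed for bromine in this place. The steps among compound 2, compound 3 and compound 4 cannot be read, and the two bromine placements cannot be told apart in this assay.

As far as these compounds go, whether any group on the triazole nitrogen gives a number clearly lower than that of compound 1 stays open, for example a phenyl bearing an amine or a carboxylic acid, or a longer chain in place of the aryl ring. Also open, from the compounds shown here alone, is how far past the limit compound 2, compound 3 and compound 4 lie, and whether they differ from one another at all.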